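The source may report more compounds than this note shows. Statements on the series, on what has been measured and on what is new or still open speak of the compounds shown alone.

Measured so far:
Compound 1, `C=CCn1c(SCC(=O)Nc2ccc(C(C)=O)cc2)nnc1-c1ccccc1`, in a functional assay on the whole organism (strain albino) for inhibition, with Rattus norvegicus as the target, read by paw edema, with stated times of 30 min and 4 h, at a dose of 0.28 mmol/kg by the oral route (a lower number here means less inhibition, a higher number more inhibition at the dose given (going by the name of the read-out)), compound 1 gives 70%.
Compound 2, `C=CCn1c(SCC(=O)Nc2ccc(/C(C)=N/O)cc2)nnc1-c1ccccc1`, in this assay compound 2 gives 73%.
Compound 3, `C=CCn1c(SCC(=O)Nc2ccc(/C(C)=N/O)cc2)nnc1-c1ccc(OC)cc1`, in this assay compound 3 gives 75%.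

All three numbers lie within the usual scatter of one another, so no order among them can be read from these data.

Compound 4, `C=CCn1c(SCC(=O)Nc2ccc(C(C)=O)cc2)nnc1-c1ccc(OC)cc1`, has not yet been measured. It differs from compound 3 by one change, (a group of 3 heavy atoms (2 carbon, 1 oxygen; no ring) in place of a group of 4 heavy atoms (2 carbon, 1 nitrogen, 1 oxygen; no ring), on an aromatic carbon). The same change occurs once among the measured compounds, from compound 2 to compound 1, as a group of 3 heavy atoms (2 carbon, 1 oxygen; no ring) in place of a group of 4 heavy atoms (2 carbon, 1 nitrogen, 1 oxygen; no ring), on an aromatic carbon, and there it made a number 3 percentage points lower from compound 2 to compound 1 (within the scatter). The cores of the two pairs differ in the way compound 3 differs from compound 2, (methoxy in place of hydrogen on an aromatic carbon), a change that made a number 2 percentage points higher from compound 2 to compound 3 (within the scatter). The place of the change is described in the same words in both pairs, so the step from compound 3 to compound 4 is the same change.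

Compound 4 is expected to show a number 3 percentage points lower from compound 3 to compound 4 (within the scatter), a step of about the same small size as the earlier one, because a number 3 percentage points lower from compound 2 to compound 1 (within the scatter) fell within the scatter. Compound 4 is therefore estimated at 72%, with a likely range from 62% to 82%.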

Compound 4, a percentage reported as inhibition, in the whole organism at one dose (the size of the read-out at that dose, not a potency): 68%
Estimate against measurement, compound 4: 4 percentage points above; measured number inside the range.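

In this assay, acetyl in place of the larger group on the aromatic ring gives a number 7 percentage points lower from compound 3 to compound 4 (within the scatter), and this agrees with the earlier reading of the same change on the other core: the same change on two cores in this assay, a number 3 percentage points lower (within the scatter) from compound 2 to compound 1 and a number 7 percentage points lower (within the scatter) from compound 3 to compound 4, 4 percentage points apart, within the scatter of two such steps. Methoxy in place of hydrogen, read on the two acetyl compounds, gives a number 2 percentage points lower from compound 1 to compound 4 (within the scatter), and this too does not differ from its earlier reading: the same change on two cores in this assay, a number 2 percentage points higher (within the scatter) from compound 2 to compound 3 and a number 2 percentage points lower (within the scatter) from compound 1 to compound 4, 4 percentage points apart, within the scatter of two such steps. Every step here lies within the scatter: the data show no measurable effect of either change on these cores, and they do not show that the steps are truly equal or that a small real effect is absent.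

The compounds shown leave open whether a carboxylic acid or an amine in place of acetyl, or chloro in place of methoxy, would move the number beyond the scatter. Going by these compounds, all readings come from a single dose, so how these compounds compare in potency also remains open.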